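The source may hold more compounds than are shown below. What is called first, only, known or untested is meant among the compounds shown, and "the series" means these compounds.

Measured so far in an assay on isolated protein (Cavia porcellus) with Sigma non-opioid intracellular receptor 1 (Homo sapiens) as the target, read by radioligand binding; a lower number here means a stronger inhibitor, a higher number a weaker inhibitor: compound 1 `CN(C)CCCCCCCCCCOc1ccc2oc(-c3ccccc3)cc(=O)c2c1` gives 297 nM; compound 2 `O=c1cc(-c2ccccc2)oc2ccc(OCCCCCCN3CCNCC3c3ncccn3)cc12` gives 1630 nM. Within the data shown here, compound 2 thus stands highest of the two numbers, its only neighbour being compound 1 with a 5.5-fold higher number from compound 1 to compound 2 (0.74 log units; beyond the scatter).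

Compound 3 `CCOC(=O)C1CCN(CCCCCCOc2ccc3oc(-c4ccccc4)cc(=O)c3c2)CC1` differs from compound 2 by 4-(ethoxycarbonyl)piperidin-1-yl in place of 2-(pyrimidin-2-yl)piperazin-1-yl on a saturated chain carbon, six bonds along the chain from an oxygen on an aromatic ring. Among the measured compounds shown here, only the step from compound 1 to compound 2 bears on this change, and only loosely, since it swapped a different pair of groups at the same place. Compound 3 is expected to fall between the two measured numbers, with a step of a 3.6-fold lower number from compound 2 to compound 3 (0.56 log units; beyond the scatter) in this assay. The estimate for compound 3 is 450 nM, within 130 nM to 1500 nM.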

Compound 3, half-maximal inhibitory concentration: 164 nM
Estimate against measurement, compound 3: 2.7-fold (0.44 log units) above; low and high end bracket the measured number.
By their numbers in this assay, from the lowest: compounds 3 and 1 (each within the scatter of the next); then compound 2.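

In this assay, the place on a saturated chain carbon, six bonds along the chain from an oxygen on an aromatic ring, shows a wide span: a 9.9-fold lower number from compound 2 to compound 3 (1.00 log units; beyond the scatter) comes with 4-(ethoxycarbonyl)piperidin-1-yl replacing 2-(pyrimidin-2-yl)piperazin-1-yl. Against 4-(dimethylamino)butyl, the same group gives a 1.8-fold lower number from compound 1 to compound 3 (0.26 log units; within the scatter), so compound 1 and compound 3 cannot be ordered, and only compound 2 stands apart. No supporting data bear on the reason for these differences.

Open, from the compounds shown here alone, is what the ethoxycarbonyl contributes: an unsubstituted piperidin-1-yl or a carboxylic acid in its place would test that.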